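The source may report more compounds than this note shows. Statements on the series, on what has been measured and on what is new or still open speak of the compounds shown alone.

Compound 1 `COc1cc2c(Oc3ccc(NC(=O)c4nn(-c5ccccc5C)c(=O)cc4C)cc3F)ccnc2cc1OCCCN1CCC(C)CC1` and compound 3 `COc1cc2c(Oc3ccc(NC(=O)c4nn(-c5ccccc5C(F)(F)F)c(=O)cc4C)cc3F)ccnc2cc1OCCCN1CCC(C)CC1` are built on the same core and differ only in trifluoromethyl in place of methyl on an aromatic carbon. In a functional assay on NCI-H460 cells (Homo sapiens) for inhibition, read by MTT assay, with a stated time of 72 h (a lower number here means a stronger inhibitor, a higher number a weaker inhibitor), compound 1 gives 2260 nM, while compound 3 gives 200 nM, so the measured step is an 11-fold lower number from compound 1 to compound 3 (1.05 log units; beyond the scatter). Compound 2 `COc1cc2c(Oc3ccc(NC(=O)c4nn(-c5ccccc5C)c(=O)cc4C)cc3F)ccnc2cc1OCCCN1CCN(C)CC1` is compound 1 carrying (4-methylpiperazin-1-yl in place of 4-methylpiperidin-1-yl on a saturated chain carbon, three bonds along the chain from an oxygen on an aromatic ring); in this assay compound 2 gives 3420 nM, a step of a 1.5-fold higher number from compound 1 to compound 2 (0.18 log units; within the scatter). Compound 4 `COc1cc2c(Oc3ccc(NC(=O)c4nn(-c5ccccc5C(F)(F)F)c(=O)cc4C)cc3F)ccnc2cc1OCCCN1CCN(C)CC1` has not yet been measured and stands to compound 3 as compound 2 stands to compound 1: the change is 4-methylpiperazin-1-yl in place of 4-methylpiperidin-1-yl on a saturated chain carbon, three bonds along the chain from an oxygen on an aromatic ring, and it sits at the same place as in the first pair, so it is the same change made on the core of compound 3 rather than that of compound 1. Among the compounds with values here, since the only evidence for this change is the step from compound 1 to compound 2, the expected step from compound 3 to compound 4 in this assay is a 1.5-fold higher number from compound 3 to compound 4 (0.18 log units; within the scatter), resting on a 1.5-fold higher number from compound 1 to compound 2 (0.18 log units; within the scatter). Compound 4 is therefore estimated at 300 nM, expected to fall between 150 nM and 600 nM.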

Compound 4, half-maximal inhibitory concentration: 240 nM
Compound 4: middle estimate off by 1.3-fold (0.10 log units), on the high side; the range from low to high includes it.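

In this assay, 4-methylpiperazin-1-yl in place of 4-methylpiperidin-1-yl gives a 1.2-fold higher number from compound 3 to compound 4 (0.08 log units; within the scatter), and this change behaves alike on both cores: the same change on two cores in this assay, a 1.5-fold higher number (0.18 log units; within the scatter) from compound 1 to compound 2 and a 1.2-fold higher number (0.08 log units; within the scatter) from compound 3 to compound 4, 1.3-fold (0.10 log units) apart, within the scatter of two such steps. Trifluoromethyl in place of methyl on an aromatic carbon gives a 14-fold lower number from compound 2 to compound 4 (1.15 log units; beyond the scatter), so this large step also carries over from one core to the other: the same change on two cores in this assay, an 11-fold lower number (1.05 log units; beyond the scatter) from compound 1 to compound 3 and a 14-fold lower number (1.15 log units; beyond the scatter) from compound 2 to compound 4, 1.3-fold (0.10 log units) apart, within the scatter of two such steps. Within these compounds the two changes therefore read as independent of each other, but each rests on just two cores in one cell assay, which shows nothing about other cores or other assays.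

The compounds shown leave open whether another amine at the end of the chain, such as morpholine or dimethylamine, or a shorter or longer chain than the propyl one, would fit the same picture. On these data alone, it also remains open whether chlorine or methoxy in place of trifluoromethyl on that aromatic carbon would give a step of similar size.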